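The source may hold more compounds than are shown below. What is called first, only, known or untested is meant among the compounds shown, and "the series" means these compounds.

Measured so far in an ADME assay on HepG2 cells (Homo sapiens) for cytotoxicity, read by CellTiter-Glo and resazurin assay, with a stated time of 72 h; a lower number here means that less compound is needed, a higher number that more compound is needed for the effect:
- Compound 1 `CCOC(=O)CCCCCOc1cccc(CN(C(=O)c2ccc(-c3ccncc3)cc2)C(C)C)c1`: > 26000 nM
- Compound 2 `CCOC(=O)CCCCCOc1cccc(CN(C(=O)c2ccc(-c3cccc(F)c3)cc2)C(C)C)c1`: > 26000 nM
- Compound 3 `CCOC(=O)CCCCCOc1cccc(CN(C(=O)c2ccc(-c3cccc(CC(=O)O)c3)cc2)C(C)C)c1`: > 26000 nM

Compound 3 gives only a limit, > 26000 nM, and not a number. The same holds across the series: the limit of > 26000 nM in this assay, at which 3 of the 3 values shown sit.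

Compound 4 `CCOC(=O)CCCCCOc1cccc(CN(C(=O)c2ccc(Br)cc2)C(C)C)c1` has bromo in place of 3-(carboxymethyl)phenyl on an aromatic carbon, para to a large group: bromo in place of 3-(carboxymethyl)phenyl on an aromatic carbon. Three measured steps alter this same substituent: a step that the two limits leave unreadable from compound 1 to compound 2, a step that the two limits leave unreadable from compound 1 to compound 3 and a step that the two limits leave unreadable from compound 2 to compound 3. None of them has a size that can be read, and none brings in bromo, so they offer only weak guidance. Still, all three changes leave the compounds at the same limit in this assay, and compound 4 is expected to stay close to it, quite possibly reported as a limit again. The expected change is a step that the limit leaves unreadable from compound 3 to compound 4, with no step beyond the usual scatter and no firm direction anticipated. For compound 4 the estimated half-maximal effective concentration is 28000 nM, within an expected range of 11000 nM to 60000 nM.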

Compound 4, half-maximal effective concentration: > 26000 nM
Compound 4: a limit, no number (the forecaster's own chance of this, stated with the estimate: 80%); the middle value does not contradict the limit.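

Compound 4 gives a limit and not a number, like compound 1, compound 2 and compound 3, and no step among these four compounds can be read in this assay. The compounds shown leave open what concentration any of them needs for the effect, and whether changing the group on the aromatic carbon alters it in this assay.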